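This account rests on a few compounds, and the source may have more. Where it says the series, first, only, none or still open, it means among the compounds named here.

Measured so far in a functional assay on A549 cells (Homo sapiens) for cytotoxicity, read by sulforhodamine B assay; a lower number here means a stronger inhibitor, a higher number a weaker inhibitor:
- compound 1 `C=C1[C@@H](OC(C)=O)C[C@@H]2[C@](C)(COC=O)[C@H](OC(C)=O)CC[C@@]2(C)[C@@H]1C[C@@H](Nc1ccc(OC)c(OC)c1)C1=CCOC1=O`: > 50000 nM
- compound 2 `C=C1[C@@H](OC(C)=O)C[C@@H]2[C@](C)(COC=O)[C@H](OC(C)=O)CC[C@@]2(C)[C@@H]1C[C@@H](Nc1cccc2ccccc12)C1=CCOC1=O`: 35600 nM

The value of compound 1 is a limit of this assay, not a number. Among the compounds with values here, compound 2 therefore holds the only number, 35600 nM, and no fuller ranking is possible.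

Next in the series is compound 3 `C=C1[C@@H](OC(C)=O)C[C@@H]2[C@](C)(COC=O)[C@H](OC(C)=O)CC[C@@]2(C)[C@@H]1C[C@@H](Nc1ccc(C(=O)O)cc1)C1=CCOC1=O`, with this change: 4-carboxyphenyl in place of naphthalen-1-yl on an amine nitrogen. In short, 4-carboxyphenyl stands in place of naphthalen-1-yl on an amine nitrogen.

Within the data shown here, one measured step bears on this, made at the same nitrogen: an at least 1.4-fold lower number from compound 1 to compound 2 (0.14 log units; that floor lies within the scatter). It is small, and its floor does not clear the scatter, so it gives weak guidance. Compound 3 returns to a single aromatic ring, as in compound 1, which sits at the limit of > 50000 nM in this assay, at which 1 of the 2 values shown sits. A modest move towards a higher number is therefore expected in this assay, with no firm case for a large one. The step expected is a 1.3-fold higher number from compound 2 to compound 3 (0.10 log units; within the scatter). The assay may well report only a limit. For compound 3 the estimate is 45000 nM, with an expected range of 18000 nM to 100000 nM.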

Compound 3, half-maximal inhibitory concentration: > 50000 nM
Compound 3: a limit, no number; the forecaster's own chance of this, stated with the estimate: 55%; at least 1.1-fold (0.04 log units) between middle value and limit.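

In this assay, 4-carboxyphenyl in place of naphthalen-1-yl on the amine nitrogen can be read only as a floor: an at least 1.4-fold higher number from compound 2 to compound 3 (0.14 log units; that floor lies within the scatter). Compound 3 gives > 50000 nM, which is a limit of the assay and not a number. The two compounds with a single aromatic ring on this nitrogen, compound 1 with 3,4-dimethoxyphenyl and compound 3 with 4-carboxyphenyl, both end at the limit, so the step between them cannot be read and compound 2 with naphthalen-1-yl keeps the only number in the series: the limit of > 50000 nM in this assay, at which 2 of the 3 values shown sit.

The compounds shown leave open how far compound 1 and compound 3 lie from the limit, and whether the number of compound 2 depends on its second aromatic ring or on the absence of the substituents carried by the other two. A plain phenyl, a naphthalen-2-yl or a methyl ester of the carboxylic acid on the same nitrogen would separate these readings, although with two of the three results at the limit, any gain in this series remains to be shown.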